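Cytotoxicity of Three Measured Compounds and One Expected Value

The source may hold more compounds than are shown below. What is called first, only, known or untested is meant among the compounds shown, and "the series" means these compounds.

Compound 1, `COc1ccc(F)cc1CNCCCNc1ccnc2cc(Cc3ccc(C#N)cc3)ccc12`, gives 6050 nM.
Compound 2, `COc1ccc(Oc2ccc3c(NCCCNCc4cc(F)ccc4OC)ccnc3c2)cc1`, gives 7000 nM.
Compound 3, `COc1ccc(Oc2ccc3c(NCCCNCc4ccco4)ccnc3c2)cc1`, gives 5300 nM.

All three numbers come from an ADME assay on HepG2 cells (Homo sapiens) for cytotoxicity, read by luminescence, CellTiter-Glo and ATP content, with a stated time of 72 h; a higher number here means that more compound is needed for the effect, a lower number that less compound is needed. Compound 2 and compound 1 differ in one place: 4-cyanobenzyl in place of 4-methoxyphenoxy on an aromatic carbon. That change made the step of a 1.2-fold lower number from compound 2 to compound 1 (0.06 log units; within the scatter). The cores of compound 2 and compound 3 differ in another place: furan-2-yl in place of 5-fluoro-2-methoxyphenyl on a saturated chain carbon bound to an amine nitrogen. That difference gave the step of a 1.3-fold lower number from compound 2 to compound 3 (0.12 log units; within the scatter). So far, no change among these three compounds has moved the read-out beyond the usual scatter.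

Compound 4, `N#Cc1ccc(Cc2ccc3c(NCCCNCc4ccco4)ccnc3c2)cc1`, has not yet been measured in this assay. It differs from compound 3 as follows: 4-cyanobenzyl in place of 4-methoxyphenoxy on an aromatic carbon. The place is described in the same words as for the pair of compound 2 and compound 1, so this is the same change seen a second time. For compound 4 the expected step is a 1.2-fold lower number from compound 3 to compound 4 (0.06 log units; within the scatter), beside the earlier 1.2-fold lower number from compound 2 to compound 1 (0.06 log units; within the scatter), on which this expectation rests. Compound 4 is therefore estimated at 4600 nM, with a range from 2500 nM to 8500 nM.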

Compound 4, half-maximal effective concentration: 7910 nM
Compound 4: middle estimate off by 1.7-fold (0.24 log units), on the low side; the measured number falls inside the stated range.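

In this assay, within the data shown here, 4-cyanobenzyl in place of 4-methoxyphenoxy on an aromatic carbon gave a 1.5-fold higher number from compound 3 to compound 4 (0.17 log units; within the scatter), and beside the earlier case this step does not differ from it beyond what repeated measurements allow: the same change on two cores in this assay, a 1.2-fold lower number (0.06 log units; within the scatter) from compound 2 to compound 1 and a 1.5-fold higher number (0.17 log units; within the scatter) from compound 3 to compound 4, 1.7-fold (0.24 log units) apart, within the scatter of two such steps The furan-2-yl change gave a 1.3-fold higher number from compound 1 to compound 4 (0.12 log units; within the scatter), and the comparison reads the same way: the same change on two cores in this assay, a 1.3-fold lower number (0.12 log units; within the scatter) from compound 2 to compound 3 and a 1.3-fold higher number (0.12 log units; within the scatter) from compound 1 to compound 4, 1.7-fold (0.24 log units) apart, within the scatter of two such steps Both changes thus carried from one core to the other without any step beyond the scatter, but this does not show that either change has an effect of its own or a size that transfers, as each was seen on only two cores and every step here lies within the scatter.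

The compounds shown leave open whether a different group, such as a morpholine or a carboxylic acid in place of 4-cyanobenzyl, or a longer chain joining the two amine nitrogens, would move the read-out beyond the scatter. They also leave open whether either change would behave the same way on a third core.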